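A few compounds are considered here, and "the series" means these few. Any claim that something is new, unique, unknown or untested is made for them only; others in the source may bear on it.

In an ADME assay on Vero cells (Chlorocebus sabaeus) for cytotoxicity, read by MTT assay (on this read-out lower numbers stand for stronger inhibition and higher numbers for weaker inhibition), two compounds with a shared core have been measured so far. Compound 1 `C=CCOc1cc(OC)c(C(=O)/C=C/c2ccc(C)cc2)c(OCC=C)c1` gives 211000 nM, and compound 2 `C=CCOc1cc(OC)c(C(=O)/C=C/c2ccc(OC)cc2)c(OCC=C)c1` gives 99900 nM, the lower of the two numbers. The next compound to be read is compound 3 `C=CCOc1cc(OC)c(C(=O)/C=C/c2ccc([N+](=O)[O-])cc2)c(OCC=C)c1`. It departs from compound 2 in a single place: nitro in place of methoxy on an aromatic carbon. Nitro takes the place of methoxy on an aromatic carbon, para to a large group, so that 4-methoxyphenyl becomes 4-nitrophenyl. Going by the values given here, only one measured step bears on this change: a 2.1-fold lower number from compound 1 to compound 2 (0.32 log units; beyond the scatter), where methoxy took the place of methyl on an aromatic carbon. Among the compounds with values here, that step was modest, and it offers no direct guide to nitro, which no measured compound carries. With so little evidence, no step beyond the scatter is expected in this assay, and the direction remains uncertain. The expected change is a 1.2-fold lower number from compound 2 to compound 3 (0.10 log units; within the scatter). For compound 3 the estimated value is 80000 nM, with an expected range from 25000 nM to 230000 nM.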

Compound 3, half-maximal inhibitory concentration: 12600 nM
Beside the measured number, compound 3's estimate is 6.3-fold (0.80 log units) above it; the whole stated range lies above it.
By their numbers in this assay, from the lowest: compound 3; then compound 2; then compound 1.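

In this assay nitro in place of methoxy gives a 7.9-fold lower number from compound 2 to compound 3 (0.90 log units; beyond the scatter) and so shows that this place on the aromatic ring, para to a large group, can move the read-out much further than the earlier swap of methyl for methoxy indicated. Going by these compounds alone, measured against methyl, nitro gives a 17-fold lower number from compound 1 to compound 3 (1.22 log units; beyond the scatter) and this is the widest step among the three compounds, which puts compound 3 lowest, compound 2 in the middle and compound 1 highest, with no compound going against that order. Nothing measured here accounts for the size of these steps or for the order of the three groups.

Three groups at a single place cannot show whether the number would keep falling or turn back with another group there, such as an amine, a carboxylic acid or a nitrile. Going by these compounds, it also remains open whether nitro would give a step of similar size elsewhere on the same ring, or on a core that carries something other than the two allyloxy groups.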